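From furan-3-yl to phenyl at the assay limit

The source may report more compounds than this note shows. Statements on the series, on what has been measured and on what is new or still open speak of the compounds shown alone.

Going by the values given here, in a functional assay on K562 cells (Homo sapiens), read by MTT assay, with a stated time of 72 h (on this read-out higher numbers stand for weaker inhibition and lower numbers for stronger inhibition), compound 1 `COc1ncnc2c1c(-c1cc3ccccc3o1)cn2[C@@H]1O[C@H](CO)[C@@H](O)[C@H]1O` gives 20900 nM, the only actual number among the measured compounds. Compound 2 `CNc1ncnc2c1c(-c1cc3ccccc3o1)cn2[C@@H]1O[C@H](CO)[C@@H](O)[C@H]1O` gives only a limit, > 20000 nM. Among the compounds with values here, the one measured step is therefore a step that the limit leaves unreadable from compound 1 to compound 2, and it exchanges methoxy for methylamino, not the group at issue here. Compound 3 `COc1nc(N)nc2c1c(-c1ccoc1)cn2[C@@H]1O[C@H](CO)[C@@H](O)[C@H]1O` also gives only a limit, > 20000 nM. Its place on the numbers is thus (the limit of > 20000 nM in this assay, at which 2 of the 3 values shown sit), with no exact value.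

Compound 4 `COc1nc(N)nc2c1c(-c1ccccc1)cn2[C@@H]1O[C@H](CO)[C@@H](O)[C@H]1O` differs from compound 3 by phenyl in place of furan-3-yl on an aromatic carbon, which is phenyl in place of furan-3-yl on an aromatic carbon. Within the data shown here, no measured step covers this exchange, so the data offer no basis for a shift in either direction. In this assay, no change beyond the scatter is expected. The expected step is a step that the limit leaves unreadable from compound 3 to compound 4. The reading that compound 1 gives, 20900 nM, suggests that weak values are the likeliest outcome. For compound 4 the estimated value is 25000 nM, with an expected range from 10000 nM to 50000 nM.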

Compound 4, half-maximal inhibitory concentration: > 20000 nM
Compound 4 was reported as a limit (the forecaster's own chance of this, stated with the estimate: 80%); the middle value is on the limit's open side.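

Compound 3 and compound 4 are both reported only as limits in this assay, and the step between them, phenyl in place of furan-3-yl, cannot be read. The compounds shown leave open whether this exchange changes inhibition in either direction.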